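The source may report more compounds than this note shows. Statements on the series, on what has been measured and on what is new or still open speak of the compounds shown alone.

Measured so far:
compound 1 `C#CCCCC#Cc1nc(NCc2cccc(Cl)c2)c2ncn([C@@H]3[C@H](O)[C@H](O)[C@]4(C(=O)NC)C[C@H]34)c2n1`: 36%
compound 2 `CNC(=O)[C@@]12C[C@@H]1[C@@H](n1cnc3c(NCc4cccc(Cl)c4)nc(C#CCCCCc4cn(-c5ccc(C(=O)O)cc5)nn4)nc31)[C@H](O)[C@@H]2O`: 0%

In an assay on CHO cells for displacement of a labelled ligand from adenosine receptor A1 (Homo sapiens), read by scintillation counting, tested at 10 uM (on this read-out higher numbers stand for more inhibition at the one concentration tested (going by the name of the read-out) and lower numbers for less inhibition), compound 1 gives 36%. Compound 2 gives 0%, the lowest of the two numbers, and the gap to compound 1 lies beyond the scatter. Within the data shown here, no step between compounds differing in one place is available, so the two values show only that much.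

Compound 3 `CNC(=O)[C@@]12C[C@@H]1[C@@H](n1cnc3c(NCc4cccc(Cl)c4)nc(C#CCCCCc4cn(-c5ccc(N=C=S)cc5)nn4)nc31)[C@H](O)[C@@H]2O` differs from compound 2 in one place: a group of 3 heavy atoms (1 carbon, 1 nitrogen, 1 sulfur; no ring) in place of a group of 3 heavy atoms (1 carbon, 2 oxygen; no ring), on an aromatic carbon. Among the measured compounds shown here, with no comparable step to rest on, the change is expected to give no shift beyond the scatter, a number 10 percentage points higher from compound 2 to compound 3 (within the scatter). Compound 3 is accordingly estimated at 10%, in a range from 0% to 30%.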

Compound 3, a percentage reported as inhibition, at one concentration (the size of the read-out at that concentration, not a potency): 2%
Compound 3: middle estimate off by 8 percentage points, on the high side; the range from low to high includes it.
By their numbers in this assay, from the lowest: compounds 2 and 3 (each within the scatter of the next); then compound 1.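

At the place para to a large group, on the six-membered aromatic ring of carbon only, isothiocyanate in place of carboxy gives in this assay a number 2 percentage points higher from compound 2 to compound 3 (within the scatter) and so no separable change. Losing the hydrogen-bond donor counted for carboxy therefore leaves no mark on this read-out at this position. No measurement on hand accounts for the result.

Open, on these data alone, is whether an amine or a methyl ester at this place would move the number beyond the scatter. Also open, as far as these compounds go, is whether any exchange here changes this assay at all.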